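Branching the Acid Chain of a Thromboxane Synthase Inhibitor

A few compounds are considered here, and "the series" means these few. Any claim that something is new, unique, unknown or untested is made for them only; others in the source may bear on it.

Measured so far:
compound 1 `COC(=O)CCCC/C=C(\c1ccccc1)c1cccnc1`: 100 nM
compound 2 `O=C(O)CCC/C=C(\c1ccccc1)c1cccnc1`: 30 nM

In an assay (Equus caballus) for inhibition of Thromboxane-A synthase (Homo sapiens), using microsomes (a higher number here means a weaker inhibitor, a lower number a stronger inhibitor), compound 2 gives the lowest of the two numbers, and its nearest neighbour is compound 1, with 100 nM. For the measured compounds named here, the one measured step, a 3.3-fold lower number from compound 1 to compound 2 (0.52 log units; beyond the scatter), shows that the free acid at the end of the chain gives a modestly stronger inhibitor than the methyl ester on a chain one carbon longer.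

Compound 3 `C=CCC(CCC/C=C(\c1ccccc1)c1cccnc1)C(=O)O` is not yet measured. It differs from compound 2 in one place: 1-carboxybut-3-en-1-yl in place of carboxy on a saturated chain carbon, three bonds along the chain from a double-bonded chain carbon. The acid stays at the same point of the chain; a but-3-enyl branch is added to the carbon carrying it.

Going by the values given here, no measured step touches this kind of branching. The step from compound 1 to compound 2 concerns only how the acid is presented, so it gives little guidance on an added branch. Because compound 2 already stands at 30 nM, compound 3 is expected to land near it, with a 1.3-fold higher number from compound 2 to compound 3 (0.12 log units; within the scatter), and an estimate of 40 nM (range 10 nM to 160 nM) in this assay.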

Compound 3, half-maximal inhibitory concentration: 50 nM
Beside the measured number, compound 3's estimate is 1.3-fold (0.10 log units) below it; the range from low to high includes it.
By their numbers in this assay, from the lowest: compounds 2, 3 and 1 (each within the scatter of the next, the first and the last beyond it).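

The carbon carrying the acid in compound 2 can take on a but-3-enyl branch, turning the carboxy group into 1-carboxybut-3-en-1-yl, with no change that stands clear of the usual scatter in this assay: the step is a 1.7-fold higher number from compound 2 to compound 3 (0.22 log units; within the scatter) and is small enough that the two compounds must be read as equal. Compound 3 also cannot be separated from compound 1, with a 2.0-fold lower number from compound 1 to compound 3 (0.30 log units; within the scatter) at the edge of the same scatter, even though compound 1 and compound 2 themselves stand apart, so the branched acid lies within reach of both neighbours and its place relative to them stays unresolved. Nothing available explains how the branch is accommodated at this position.

A single unsaturated branch says little about branches in general, so a small methyl group or a saturated butyl chain on the same carbon could behave differently. Going by these compounds, it also remains open how this branched compound would respond if its carboxylic acid were swapped for an amide or a tetrazole.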